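The compounds below may be only part of what the source reports. "The series", "measured", "known", "first", "only" and "open" are said of these compounds alone.

Among the compounds with values here, in a functional assay on cells for agonist activity at Glucose-dependent insulinotropic receptor (Homo sapiens), read by a luciferase reporter, with a stated time of 4 h (a lower number here means a smaller maximal response, a higher number a larger maximal response), compound 1 `CS(=O)(=O)c1ccc2c(c1)CCN2c1ncnc2c(C3CCN(c4ncccn4)CC3)coc12` gives 196%, the highest of the three numbers measured so far. Compound 2 `CC(C)(C)OC(=O)N1CCC(c2coc3c(Nc4ccc(S(C)(=O)=O)cc4F)ncnc23)CC1` gives 123%, and compound 3 `CN(c1ccc(S(C)(=O)=O)cc1F)c1ncnc2c(C3CCN(C(=O)OC(C)(C)C)CC3)coc12` gives 6%. Within the data shown here, the only step between measured compounds that differ in a single place, a number 117 percentage points lower from compound 2 to compound 3 (beyond the scatter), came with a methyl in place of hydrogen on a nitrogen on an aromatic ring. Compound 4 `CS(=O)(=O)c1ccc2c(c1)CCN2c1ncnc2c(C3CCN(c4ncc(O)cn4)CC3)coc12` differs from compound 1 in another way: hydroxy in place of hydrogen on an aromatic carbon. Among the measured compounds shown here, no measured step covers a change of this kind, and the single step available concerns a different part of the molecule, so it offers little guidance. The expectation is therefore a change within the scatter, a number 16 percentage points lower from compound 1 to compound 4 (beyond the scatter). For compound 4 the estimate is 180%, within 125% to 220%.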

Compound 4, largest response reached (Emax), in percent of the reference or control that the assay uses: 145%
Compound 4: middle estimate off by 35 percentage points, on the high side; the measured number falls inside the stated range.
By their numbers in this assay, from the lowest: compound 3; then compound 2; then compound 4; then compound 1.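

In this assay, the change from pyrimidin-2-yl to 5-hydroxypyrimidin-2-yl gives a number 51 percentage points lower from compound 1 to compound 4 (beyond the scatter), so this aromatic carbon, two atoms from the ring nitrogen, is sensitive to substitution. Within the data shown here, it is the first step measured on this ring, and a single added oxygen is enough to shift the maximal response by a large amount. Nothing available here accounts for the drop. As far as these compounds go, whether it is specific to hydroxy remains open. A methoxy or an amine on the same carbon would show whether other groups there lower the response to a similar extent.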